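Working notes: methoxy in place of chloro

This account rests on a few compounds, and the source may have more. Where it says the series, first, only, none or still open, it means among the compounds named here.

Measured in a functional assay on CHO cells for agonist activity at Free fatty acid receptor 1 (Homo sapiens), read by FLIPR, tested at 100 nM; a lower number here means a weaker effect, a higher number a stronger effect of the compound at the concentration tested:
compound 1, `O=C(O)COc1ccc(NC(=O)C(=O)Nc2ccccc2)cc1F`: 9.78%
compound 2, `O=C(O)COc1ccc(NC(=O)C(=O)Nc2ccccc2Cl)cc1F`: 10.2%

Compound 2 holds the top of the two numbers only nominally: the step of a number 0.4 percentage points higher from compound 1 to compound 2 (within the scatter) lies within the scatter, so the two compounds cannot be told apart in this assay.

Compound 3, `COc1ccccc1NC(=O)C(=O)Nc1ccc(OCC(=O)O)c(F)c1`, differs from compound 2 by methoxy in place of chloro on an aromatic carbon.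

Among the compounds with values here, one measured step touches the same position: chloro in place of hydrogen on an aromatic carbon, a number 0.4 percentage points higher from compound 1 to compound 2 (within the scatter), within the scatter. Within the data shown here, it shows that putting chloro at this carbon changed nothing measurable, but no step with methoxy entering is on hand, so the bearing is loose. Among the measured compounds shown here, with the only related step flat, the expectation for compound 3 in this assay is no movement beyond the scatter, as step a number 0.2 percentage points lower from compound 2 to compound 3 (within the scatter).

Compound 3 is therefore estimated at 10%, with a range from 2% to 25%.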

Compound 3, a percentage reported as activity, at one concentration (the size of the read-out at that concentration, not a potency): 6.78%
The estimate for compound 3 lay 3.2 percentage points above the measured number; measured number inside the range.
By their numbers in this assay, from the lowest: compounds 3, 1 and 2 (each within the scatter of the next).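

In this assay, the change from 2-chlorophenyl to 2-methoxyphenyl gives a number 3.4 percentage points lower from compound 2 to compound 3 (within the scatter) and stays flat, and methoxy in place of hydrogen gives a number 3 percentage points lower from compound 1 to compound 3 (within the scatter) on the same aromatic carbon. This carbon, ortho to a large group, has now carried hydrogen, chloro and methoxy with no step beyond the scatter, so methoxy, like chloro, cannot be told apart from hydrogen here. Nothing on hand offers an explanation for this flat result.

On these data alone, whether an amine, a carboxylic acid or a longer alkoxy chain on this carbon would move the read-out beyond the scatter remains open. Also open, as far as these compounds go, is whether the three compounds would separate in potency, since a read-out at one concentration does not give it.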